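Larger Chain Ends on Compound 1 and Cell Growth

A few compounds are considered here, and "the series" means these few. Any claim that something is new, unique, unknown or untested is made for them only; others in the source may bear on it.

Compound 1 `CCCOc1c(-c2cc(OC)c(OC)c(OC)c2)oc2ccccc2c1=O` is the starting point of this short series. In a functional assay on DU-145 cells (Homo sapiens) for antiproliferative activity, read by WST assay, with a stated time of 3 days (a higher number here means a weaker inhibitor, a lower number a stronger inhibitor), compound 1 gives 2800 nM. For the measured compounds named here, that is the only plain number among the three measured compounds.

Compound 2 `CCCCOc1c(-c2cc(OC)c(OC)c(OC)c2)oc2ccccc2c1=O` differs from compound 1 by methyl in place of hydrogen on a saturated chain carbon, three bonds along the chain from an oxygen on an aromatic ring. In this assay compound 2 reaches only the limit of the measurement, > 50000 nM. That amounts to an at least 17-fold higher number from compound 1 to compound 2 (1.25 log units; beyond the scatter). Compound 3 `CCCN(CCC)CCCOc1c(-c2cc(OC)c(OC)c(OC)c2)oc2ccccc2c1=O` puts dipropylamino in the same place. In this assay compound 3 likewise gives only a limit, > 50000 nM. That amounts to an at least 17-fold higher number from compound 1 to compound 3 (1.25 log units; beyond the scatter). Between the two there is a step that the two limits leave unreadable from compound 2 to compound 3. Both additions therefore run into (the limit of > 50000 nM in this assay, at which 2 of the 3 values shown sit).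

Compound 4 `CCCCCN(CCCCC)CCCCOc1c(-c2cc(OC)c(OC)c(OC)c2)oc2ccccc2c1=O` changes compound 1 by (dipentylamino)methyl in place of hydrogen on a saturated chain carbon, three bonds along the chain from an oxygen on an aromatic ring. Both measured changes at this position, one small and one larger, produced the same large loss, so an even larger group is expected to do no better, and the step of a 43-fold higher number from compound 1 to compound 4 (1.63 log units; beyond the scatter) is expected. Compound 4 is estimated at 120000 nM, within a range from 30000 nM to 600000 nM, and most likely the assay will again report only a limit.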

Compound 4, half-maximal inhibitory concentration: 12500 nM
Compound 4: the middle estimate sits 9.6-fold (0.98 log units) above what was measured; the measured number lies below the stated range.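

The loss at this position does not simply grow with the size of what is added: in this assay, (dipentylamino)methyl, with its 12 heavy atoms, still costs activity, but only to the extent of a 4.5-fold higher number from compound 1 to compound 4 (0.65 log units; beyond the scatter). Against the two earlier additions, whose results are only limits and not numbers, this longer amine chain stands clearly better, with an at least 4.0-fold lower number from compound 3 to compound 4 (0.60 log units; beyond the scatter) and with an at least 4.0-fold lower number from compound 2 to compound 4 (0.60 log units; beyond the scatter). A large group is therefore tolerated here to a degree the earlier compounds gave no sign of, and compound 2 and compound 3 are the ones that do not fit this easing: the limit of > 50000 nM in this assay, at which 2 of the 4 values shown sit.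

What the compounds shown leave open is which part of the change matters, since the step to compound 4 alters the amine ends and the chain leading to them together. A dibutylamino end or a piperidine on the same chain would help to separate those two parts, and a longer plain chain such as hexyl, with no nitrogen, would test whether the amine is needed at all.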